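Swapping tert-butyl for methoxy in a cytotoxicity series

This account rests on a few compounds, and the source may have more. Where it says the series, first, only, none or still open, it means among the compounds named here.

Compound 1 `COc1ccc(/C=C2\S/C(=N\c3ccc(C(C)(C)C)cc3)N(C)C2=O)cc1` is one of three compounds tested in an ADME assay on TERT-RPE1 cells (Homo sapiens) for cytotoxicity, read by MTT assay, with a stated time of 72 h (a higher number here means a weaker inhibitor, a lower number a stronger inhibitor), where compound 1 gives 46700 nM. Compound 2 `COc1ccc(/C=C2/CN(C)/C(=N/c3ccc(Cl)cc3)S2)cc1` gives 39600 nM and compound 3 `COc1ccc(/C=C2/CN(C)/C(=N/c3ccc(OC)cc3)S2)cc1` gives 65900 nM; all three lie within the scatter of one another, so compound 1 cannot be set apart from the others. Compound 4 `COc1ccc(/C=C2\S/C(=N\c3ccc(OC)cc3)N(C)C2=O)cc1` differs from compound 1 by a single change: methoxy in place of tert-butyl on an aromatic carbon. Going by the values given here, the only measured step that bears on it is a 1.7-fold higher number from compound 2 to compound 3 (0.22 log units; within the scatter), a swap into the same methoxy group in compounds built on a different core. On that basis no step beyond the scatter is expected in this assay from compound 1 to compound 4. Compound 4 is therefore expected to give 55000 nM, within 28000 nM to 110000 nM. The expected step is a 1.2-fold higher number from compound 1 to compound 4 (0.07 log units; within the scatter).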

Compound 4, half-maximal inhibitory concentration: > 100000 nM
Compound 4 ended at the assay's limit; the forecaster's own chance of this, stated with the estimate: 10%; middle value at least 1.8-fold (0.25 log units) away from the limit.
By their numbers in this assay, from the lowest: compounds 2, 1 and 3 (each within the scatter of the next). At a limit, above all of these: compound 4.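

On the core of compound 1, methoxy in place of tert-butyl gives a step that can be read in this assay: an at least 2.1-fold higher number from compound 1 to compound 4 (0.33 log units; beyond the scatter). Going by these compounds alone, the swap from chloro to methoxy on a different core gave only a 1.7-fold higher number from compound 2 to compound 3 (0.22 log units; within the scatter), so this is the first sign that a change at this place can move the number beyond the scatter. Compound 4 stands at a limit of the assay and not at a number, so the full size of its step is unknown: the limit of > 100000 nM in this assay, at which 1 of the 4 values shown sits.

On these data alone, whether the step comes from losing tert-butyl or from gaining methoxy stays open. So does how an amine or a carboxylic acid at this place would read.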